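The source may report more compounds than this note shows. Statements on the series, on what has been measured and on what is new or still open speak of the compounds shown alone.

In a functional assay on HT-1080 cells (Homo sapiens) for cytotoxicity, read by MTT assay, with a stated time of 72 h (a lower number here means a stronger inhibitor, a higher number a weaker inhibitor), three compounds sharing one core have been measured: compound 1 `COc1cccc(/C=C2\CCC/C(=C\c3ccc(Cl)cc3)C2=O)c1OC` gives 11100 nM, compound 2 `COc1cccc(/C=C2\CCC/C(=C\c3cccc(Br)c3)C2=O)c1OC` gives 12200 nM, and compound 3 `COc1cccc(/C=C2\CCC/C(=C\c3cccc(O)c3)C2=O)c1OC` gives 8500 nM. Compound 3 therefore stands level with the other two, as its number cannot be told apart from theirs. The next structure, compound 4 `COc1cccc(/C=C2\CCC/C(=C\c3ccc(Cl)cc3Cl)C2=O)c1OC`, changes one group: 2,4-dichlorophenyl in place of 3-hydroxyphenyl on a double-bonded chain carbon bound to a double-bonded ring carbon. The closest evidence is the swap of 4-chlorophenyl for 3-hydroxyphenyl, a 1.3-fold lower number from compound 1 to compound 3 (0.12 log units; within the scatter). The swap of bromo for hydroxy, a 1.4-fold lower number from compound 2 to compound 3 (0.16 log units; within the scatter), and the swap of 4-chlorophenyl for 3-bromophenyl, a 1.1-fold higher number from compound 1 to compound 2 (0.04 log units; within the scatter), point the same way, since each of these steps is small. Within the data shown here, none of the measured compounds carries 2,4-dichlorophenyl, so this evidence is indirect. No step beyond the scatter is therefore expected in this assay. The expected step is a 1.2-fold higher number from compound 3 to compound 4 (0.07 log units; within the scatter), which would stay within the scatter. For compound 4 the estimated value is 10000 nM, with an expected range of 5000 nM to 20000 nM.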

Compound 4, half-maximal inhibitory concentration: > 20000 nM
Compound 4: a limit, no number (the forecaster's own chance of this, stated with the estimate: 5%); middle value at least 2.0-fold (0.30 log units) away from the limit.
By their numbers in this assay, from the lowest: compounds 3, 1 and 2 (each within the scatter of the next). At a limit, above all of these: compound 4.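

Compound 4 gives no number in this assay, only a limit of the assay: the limit of > 20000 nM in this assay, at which 1 of the 4 values shown sits.

Among these compounds, putting 2,4-dichlorophenyl in place of 3-hydroxyphenyl, on a double-bonded chain carbon bound to a double-bonded ring carbon, gives the first step that lies beyond the scatter, an at least 2.3-fold higher number from compound 3 to compound 4 (0.37 log units; beyond the scatter), so the group at this place can matter even though the earlier swaps there stayed within the scatter. The other two comparisons are less firm: chloro in place of hydrogen gives an at least 1.8-fold higher number from compound 1 to compound 4 (0.25 log units; that floor lies within the scatter), and 2,4-dichlorophenyl in place of 3-bromophenyl gives an at least 1.6-fold higher number from compound 2 to compound 4 (0.21 log units; that floor lies within the scatter), so neither alone establishes a real change.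

On these data alone, the true size of these steps stays unknown, and so does whether the added chloro or the lost hydroxy counts for more. As far as these compounds go, what an amine or a carboxylic acid on that phenyl ring would do also remains open.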